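A few compounds are considered here, and "the series" means these few. Any claim that something is new, unique, unknown or untested is made for them only; others in the source may bear on it.

Compound 3 `CSc1cc(NC2CCCC2)cc2c(-c3ccnc(NC4CCCC4)n3)c(-c3ccc(F)cc3)nn12` is one of three compounds tested in an ADME assay on Vero cells (Chlorocebus sabaeus) for cytotoxicity; on this read-out lower numbers stand for higher toxicity in this test and higher numbers for lower toxicity in this test. Compound 1 `Nc1ccn2nc(-c3ccc(F)cc3)c(-c3ccnc(NC4CCCC4)n3)c2c1` gives 20000 nM in this assay. For compound 2 `Fc1ccc(-c2nn3c(NC4CCCC4)cc(NC4CCCC4)cc3c2-c2ccnc(NC3CCCC3)n2)cc1` the result is only a limit of the test, > 40000 nM. Compound 3 likewise reaches only a limit, > 40000 nM. Among the compounds with values here, the one step with a single change, a step that the two limits leave unreadable from compound 2 to compound 3, therefore has no readable size, and the limit of > 40000 nM in this assay, at which 2 of the 3 values shown sit, marks where compound 3 stands. Compound 4 `COCCOc1cc(NC2CCCC2)cc2c(-c3ccnc(NC4CCCC4)n3)c(-c3ccc(F)cc3)nn12` differs from compound 3 by 2-methoxyethoxy in place of methylsulfanyl on an aromatic carbon. Within the data shown here, no measured step covers this change, and the values of compound 2 and compound 3 give no direction. Compound 4 is therefore expected to remain near the limit, the step of a number no higher from compound 3 to compound 4 (the limit leaves the size open) being expected to be none beyond the scatter. The estimate for compound 4 is 40000 nM, between 15000 nM and 80000 nM.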

Compound 4, half-maximal cytotoxic concentration: 32500 nM
For compound 4 the middle estimate is 1.2-fold (0.09 log units) above the measured one, within the range that was stated.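

In this assay compound 4 gives a real number at the position next to the ring nitrogen, where compound 2 and compound 3 gave only limits. The change reads as an at least 1.2-fold lower number from compound 3 to compound 4 (0.09 log units; that floor lies within the scatter), and, with cyclopentylamino as the group replaced, as an at least 1.2-fold lower number from compound 2 to compound 4 (0.09 log units; that floor lies within the scatter); each is only a floor, so no real drop is shown. The true sizes stay open because the comparison rests on a limit: the limit of > 40000 nM in this assay, at which 2 of the 4 values shown sit.

On these data alone, how a carboxylic acid or a longer ether chain at this position would read in this assay remains open.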